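Removing the Methyl from the Aryl Ether of Compound 1

The source may report more compounds than this note shows. Statements on the series, on what has been measured and on what is new or still open speak of the compounds shown alone.

Compound 1 `COc1cc(-c2nn(-c3ccc(NC(=O)Nc4cc(C(F)(F)F)cc(C(F)(F)F)c4)cc3)cc2-c2ccncc2)ccc1Cl` carries a 4-chloro-3-methoxyphenyl group on the shared core together with a urea bearing two trifluoromethyl groups. In a functional assay on SK-MEL-5 cells (Homo sapiens) for antiproliferative activity, read by sulforhodamine B assay, with a stated time of 48 h (a lower number here means a stronger inhibitor, a higher number a weaker inhibitor), compound 1 gives 1530 nM. Compound 2 `O=C(Nc1ccc(-n2cc(-c3ccncc3)c(-c3ccc(Cl)c(O)c3)n2)cc1)Nc1ccc(Cl)c(C(F)(F)F)c1` differs from compound 1 in more than one place, carrying a 4-chloro-3-hydroxyphenyl group and a urea with a chloro group and a single trifluoromethyl group; in this assay compound 2 gives 1530 nM. The two values stand level at the digits shown, within the scatter, so neither compound can be called the stronger inhibitor.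

Compound 3 `O=C(Nc1ccc(-n2cc(-c3ccncc3)c(-c3ccc(Cl)c(O)c3)n2)cc1)Nc1cc(C(F)(F)F)cc(C(F)(F)F)c1` has not been measured yet. It differs from compound 1 by a single change: hydrogen in place of methyl on an oxygen on an aromatic ring. Among the measured compounds shown here, no pair of measured compounds differs only in this way, so the size of this step cannot be read from the data at hand. Compound 2 also bears the hydroxy group and gives 1530 nM in this assay, which suggests that the hydroxy group is at least tolerated. The expected step of a 1.2-fold lower number from compound 1 to compound 3 (0.07 log units; within the scatter) is therefore small, no larger than the scatter, with no clear direction. Compound 3 is estimated at 1300 nM, within a range from 400 nM to 4000 nM.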

Compound 3, half-maximal inhibitory concentration: 1670 nM
For compound 3 the middle estimate is 1.3-fold (0.11 log units) below the measured one; low and high end bracket the measured number.
By their numbers in this assay, from the lowest: compounds 1, 2 and 3 (each within the scatter of the next).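

Among the compounds shown here, this is the first pair that differs in this one place, so the exchange of methoxy to hydroxy can now be read directly in this assay: the step is a 1.1-fold higher number from compound 1 to compound 3 (0.04 log units; within the scatter). With the urea bearing two trifluoromethyl groups and the rest of the shared core held constant, the methyl on this oxygen can be replaced by hydrogen without the number moving beyond the scatter. At this position, then, the 4-chloro-3-methoxyphenyl and 4-chloro-3-hydroxyphenyl groups cannot be told apart by this read-out, and nothing measured here offers a reason for that result.

The compounds shown leave open whether this position would read the same with other groups, such as an amine in place of the hydroxy group or a longer chain than methyl on the oxygen. For the compounds shown here, they also leave open whether methoxy and hydroxy would stay level on a different urea, such as the one with a chloro group and a single trifluoromethyl group.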